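The source may report more compounds than this note shows. Statements on the series, on what has been measured and on what is new or still open speak of the compounds shown alone.

In a functional assay on the whole organism with Mus musculus as the target, in the hot plate test (on this read-out lower numbers stand for an effect already at smaller amounts and higher numbers for an effect only at larger amounts of compound), compound 1 `COc1ccccc1C(=O)OC1CCN(C)CC1` gives 10.6 mg/kg. Going by the values given here, compound 2 `COc1cccc(OC)c1C(=O)OC1CCN(C)CC1` gives in this assay 73.8 mg/kg, the highest of the two numbers so far, with compound 1 as its only neighbour. Among the compounds with values here, the one step recorded, a 7.0-fold higher number from compound 1 to compound 2 (0.84 log units; beyond the scatter), came with a methoxy in place of hydrogen on an aromatic carbon.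

Compound 3 `COc1cc(OC)c(C(=O)OC2CCN(C)CC2)c(OC)c1` has not yet been measured in this assay. It differs from compound 2 by methoxy in place of hydrogen on an aromatic carbon: a methoxy group enters where a hydrogen leaves, on an aromatic carbon of a six-membered aromatic ring of carbon only, meta to two methoxy groups and para to a large group. Within the data shown here, the only step that bears on this change is a 7.0-fold higher number from compound 1 to compound 2 (0.84 log units; beyond the scatter), itself a methoxy in place of hydrogen on the same ring, and it moved the number beyond the scatter. A further rise in this assay is therefore expected for compound 3, though a second methoxy need not carry the full weight of the first. The step expected for compound 3 is a 2.7-fold higher number from compound 2 to compound 3 (0.43 log units; beyond the scatter). For compound 3 the estimate in this assay is 200 mg/kg, within a range from 80 mg/kg to 500 mg/kg.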

Compound 3, dose for half-maximal effect: 11.6 mg/kg
Compound 3: the middle estimate sits 17-fold (1.24 log units) above what was measured; the measured number lies below the stated range.
By their numbers in this assay, from the lowest: compounds 1 and 3 (each within the scatter of the next); then compound 2.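

In this assay, a methoxy group placed para to a large group and meta to two methoxy groups gave a 6.4-fold lower number from compound 2 to compound 3 (0.80 log units; beyond the scatter) and so moved the number down, beyond the scatter. The earlier step of the same listed kind, a 7.0-fold higher number from compound 1 to compound 2 (0.84 log units; beyond the scatter) on the same ring, had moved the number up, so these two steps show that the name of the change alone does not fix its direction in this series: on this ring, a methoxy in place of hydrogen can go either way, depending on the case. Nothing in the available evidence explains why the two steps run in opposite directions.

Going by these compounds, what remains open is whether the fall seen with compound 3 belongs to this place on the ring as such or depends on the two methoxy groups already present, a question that a single methoxy para to a large group on the core of compound 1 would bear on. Also open, on these data alone, is how other groups at this place, such as a hydroxyl, a chlorine or an amine, would compare with methoxy on this read-out.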